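This account rests on a few compounds, and the source may have more. Where it says the series, first, only, none or still open, it means among the compounds named here.

In a functional assay on CWR22R cells (Homo sapiens) for antiproliferative activity, read by propidium iodide staining, with a stated time of 96 h (on this read-out higher numbers stand for weaker inhibition and lower numbers for stronger inhibition), compound 1 (`CC(O)(CSc1ccc(S(F)(F)(F)(F)F)cc1)C(=O)Nc1ccc(C#N)cc1C(F)(F)F`) gives 13200 nM and compound 2 (`CC(O)(COc1ccc(S(F)(F)(F)(F)F)cc1)C(=O)Nc1ccc([N+](=O)[O-])c(C(F)(F)F)c1`) gives 14100 nM in the same range. Compound 3 (`CC(O)(COc1cccc(S(F)(F)(F)(F)F)c1)C(=O)Nc1cc(C(F)(F)F)cc(C(F)(F)F)c1`) gives 2300 nM as the lowest of the three numbers, beyond the scatter from both others. Compound 4 (`CC(O)(COc1cccc(C(F)(F)C(F)(F)F)c1)C(=O)Nc1cc(C(F)(F)F)cc(C(F)(F)F)c1`) differs from compound 3 in one place: a group of 7 heavy atoms (2 carbon, 5 fluorine; no ring) in place of a group of 6 heavy atoms (5 fluorine, 1 sulfur; no ring), on an aromatic carbon (the new group is 1,1,2,2,2-pentafluoroethyl, meta to a large group). Among the compounds with values here, no measured pair shows this exchange, so no step beyond the scatter is expected in this assay for it. The estimate means a 1.2-fold lower number from compound 3 to compound 4 (0.06 log units; within the scatter) as an expected step within the scatter. Compound 4 is estimated at 2000 nM and is expected to fall from 800 nM to 5500 nM when measured.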

Compound 4, half-maximal inhibitory concentration: 4100 nM
Compound 4: the middle estimate sits 2.1-fold (0.31 log units) below what was measured; the range from low to high includes it.
By their numbers in this assay, from the lowest: compounds 3 and 4 (each within the scatter of the next); then compounds 1 and 2 (each within the scatter of the next).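

In this assay, within the data shown here, putting 1,1,2,2,2-pentafluoroethyl on this aromatic carbon in place of the group of five fluorine atoms and one sulfur gives a 1.8-fold higher number from compound 3 to compound 4 (0.25 log units; within the scatter) and is the first single-place exchange that can be read. At this place, the two groups cannot be told apart in this assay. No measured information accounts for this result. The compounds shown leave open how a methoxy group, an amine or a single chlorine atom on this carbon would compare.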